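A few compounds are considered here, and "the series" means these few. Any claim that something is new, unique, unknown or untested is made for them only; others in the source may bear on it.

Working notes on a small set of aminothienopyrimidines sharing one core. Compound 1 `Cc1ccc(-c2nc(N)c3cc(Cc4ccccc4Cl)sc3n2)o1` gives 26.1 nM in a functional assay on CHO-K1 cells for antagonist activity at adenosine receptor A1 (Homo sapiens), read by a beta-galactosidase reporter and cAMP accumulation, with stated times of 15 min and 6 h; a lower number here means a stronger inhibitor, a higher number a weaker inhibitor. Compound 2 `CC(C)c1ccc(-c2nc(N)c3cc(Cc4ccccc4)sc3n2)o1` gives 283 nM. Compound 3 `Cc1csc(-c2nc(N)c3cc(Cc4ccccc4)sc3n2)n1` gives 1490 nM and so carries the highest number of the three; its nearest neighbour on the numbers is compound 2, and compound 1 lies furthest from it. Among the measured compounds shown here, the one single-point step that is measured, a 5.3-fold higher number from compound 2 to compound 3 (0.72 log units; beyond the scatter), concerns the heteroaryl group and not the benzyl part.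

Compound 4 `Cc1csc(-c2nc(N)c3cc(Cc4ccccc4Cl)sc3n2)n1` differs from compound 3 by chloro in place of hydrogen on an aromatic carbon, on an aromatic carbon of a six-membered aromatic ring of carbon only, ortho to a large group; read one bond further out, benzyl becomes 2-chlorobenzyl. For the measured compounds named here, no measured step isolates this change. Going by the values given here, compound 1 and compound 2 differ both here and in the heteroaryl group, so the gap between their two values cannot be split between the two differences, though the chloro compound is the one with the lower number.

On that weak indication the expected step of a 3.0-fold lower number from compound 3 to compound 4 (0.47 log units; beyond the scatter) is a modest fall. Compound 4 is therefore estimated at 500 nM, with a range from 120 nM to 2000 nM.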

Compound 4, inhibition constant: 49.6 nM
Beside the measured number, compound 4's estimate is 10-fold (1.00 log units) above it; measured number outside the range, below it.
By their numbers in this assay, from the lowest: compounds 1 and 4 (each within the scatter of the next); then compound 2; then compound 3.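

Among the compounds shown here, with the 4-methyl-1,3-thiazol-2-yl group held fixed, chloro in place of hydrogen on an aromatic carbon, ortho to a large group, gives a 30-fold lower number from compound 3 to compound 4 (1.48 log units; beyond the scatter) in this assay, so this is the first isolated reading of the change and it is a large one. With 2-chlorobenzyl held fixed, 4-methyl-1,3-thiazol-2-yl in place of 5-methylfuran-2-yl gives a 1.9-fold higher number from compound 1 to compound 4 (0.28 log units; within the scatter) in this assay, a step within the scatter, so these two heteroaryl groups cannot be told apart when the chloro group is present. Nothing in hand accounts for the size of the chloro step.

For the compounds shown here, open is whether a step of this size carries over to compounds bearing 5-methylfuran-2-yl or 5-isopropylfuran-2-yl, as the only isolated reading of the chloro change comes from the 4-methyl-1,3-thiazol-2-yl pair. Also open, going by these compounds, is how fluoro, bromo, methyl or methoxy in place of chloro on the same aromatic carbon would read in this assay.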